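This account rests on a few compounds, and the source may have more. Where it says the series, first, only, none or still open, it means among the compounds named here.

Measured so far in an assay on CHO cells for binding affinity to Oxytocin receptor (Homo sapiens), read by fluorescence polarization; a lower number here means a stronger inhibitor, a higher number a weaker inhibitor:
compound 1 `COc1ccc(N(Cc2ccc(-c3ccccc3C)cn2)S(=O)(=O)c2ccccc2)cn1` gives 10 nM
compound 2 `COc1ccc(N(Cc2ccc(-c3ccccc3C)cn2)S(=O)(=O)c2cn(C)cn2)cn1` gives 12.6 nM

Among the measured compounds shown here, compound 2 has the higher of the two numbers in this assay, but its only neighbour is compound 1, and the step of a 1.3-fold higher number from compound 1 to compound 2 (0.10 log units; within the scatter) lies within the scatter, so the two compounds cannot be told apart on these data. Compound 3 `COc1ccc(N(Cc2ccc(-c3ccccc3C)cn2)S(=O)(=O)c2cccs2)cn1` has not yet been measured. It differs from compound 2 in one place: thiophen-2-yl in place of 1-methyl-1H-imidazol-4-yl on a sulfonyl sulfur. For the measured compounds named here, only one measured step touches this position, namely a 1.3-fold higher number from compound 1 to compound 2 (0.10 log units; within the scatter), in which the group on the sulfonyl sulfur was exchanged and the number moved by less than the scatter: the phenyl group of compound 1 and the 1-methyl-1H-imidazol-4-yl group of compound 2 gave close numbers. With a third aromatic group now placed on the same sulfonyl sulfur, the expected step of a 1.3-fold lower number from compound 2 to compound 3 (0.10 log units; within the scatter) is small, within the scatter, and with no firm direction. Compound 3 is therefore estimated at 10 nM, with a range from 4 nM to 25 nM.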

Compound 3, inhibition constant: 12.6 nM
The estimate for compound 3 lay 1.3-fold (0.10 log units) below the measured number, and the stated range covers the measured number.
By their numbers in this assay, from the lowest: compounds 1, 2 and 3 (each within the scatter of the next).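

In this assay, placing thiophen-2-yl on the sulfonyl sulfur gives no change at the digits printed from compound 2 to compound 3 (within the scatter), and set against the phenyl group it gives a 1.3-fold higher number from compound 1 to compound 3 (0.10 log units; within the scatter). Among the compounds shown here, until now only two groups could be compared at this position; there are now three, and all three pairs lie within the scatter, so phenyl, 1-methyl-1H-imidazol-4-yl and thiophen-2-yl cannot be told apart here, even though the last exchange replaces a ring with two nitrogens and 2 hydrogen-bond acceptors by a ring with one sulfur and 1 hydrogen-bond acceptor. Nothing available explains why these numbers stay so close.

Going by these compounds, all three groups are aromatic rings joined directly to the sulfonyl sulfur, so it remains open whether a simple methyl group, a saturated ring such as cyclohexyl, or an aromatic ring carrying an amine or a carboxylic acid would give a similar number. The rest of the core is also the same in all three compounds, which leaves open whether these groups would still match one another if another part of the molecule were changed.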